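Sulfonamide series: three limits and one open step

The source may report more compounds than this note shows. Statements on the series, on what has been measured and on what is new or still open speak of the compounds shown alone.

Measured so far:
- compound 1 `O=S(=O)(Nc1ccc(-c2nc3ccccc3o2)cc1)c1cccs1`; in an assay on isolated protein for inhibition of malate dehydrogenase, mitochondrial (Sus scrofa), with stated times of 45 min and 30 min (on this read-out higher numbers stand for weaker inhibition and lower numbers for stronger inhibition), compound 1 gives > 63000 nM, which is a limit of the assay.
- compound 2 `Cc1ccccc1S(=O)(=O)Nc1ccc2oc(-c3ccccc3)nc2c1`; in this assay compound 2 gives > 63000 nM, again a limit.
- compound 3 `O=S(=O)(Nc1ccc(-c2nc3ccccc3o2)cc1)c1ccccc1C(F)(F)F`; in this assay compound 3 gives > 63000 nM, also a limit.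

Compound 1 therefore stands nowhere in particular among the numbers: it sits at a limit, and so do the two further values, as summed up by the limit of > 63000 nM in this assay, at which 3 of the 3 values shown sit. Within the data shown here, no two measured compounds differ in one place only, so no step between measured values can be read, and nothing in the data ranks compound 1 against compound 2 or compound 3.

The open step leads from compound 1 to compound 4 `COc1ccc(Cl)cc1S(=O)(=O)Nc1ccc(-c2nc3ccccc3o2)cc1`. The change is 5-chloro-2-methoxyphenyl in place of thiophen-2-yl on a sulfonyl sulfur. Among the measured compounds shown here, with all three values at a limit, there is no measured step of any size to build on, and no change beyond the scatter is expected: the step that the limit leaves unreadable from compound 1 to compound 4 is the estimate, meaning compound 4 is expected to remain at or near the limit. The estimate for compound 4 in this assay is 100000 nM, with a range from 30000 nM to 300000 nM, most likely again reported only as a limit.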

Compound 4, half-maximal inhibitory concentration: > 63000 nM
Compound 4 gave a limit, no number; the forecaster's own chance of this, stated with the estimate: 85%; the middle value lies beyond the limit too.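

In this assay compound 4 gives > 63000 nM, which is a limit, so the step from compound 1 to compound 4 cannot be read. The series now sits at a single limit: the limit of > 63000 nM in this assay, at which 4 of the 4 values shown sit.

The compounds shown leave open whether any group on the sulfonyl sulfur yields a measurable value in this assay.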